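Fluoro for Methyl: Expected Cytotoxicity of Compound 4

The source may report more compounds than this note shows. Statements on the series, on what has been measured and on what is new or still open speak of the compounds shown alone.

This account concerns three compounds measured in an ADME assay on L929 cells (Mus musculus) for cytotoxicity, read by resazurin assay, with a stated time of 72 h (a higher number here means a weaker inhibitor, a lower number a stronger inhibitor), and a fourth not yet measured. Compound 1 `Cc1ccc(C(=O)/C=C/c2ccc3c(c2)B(O)OC3)cc1` is the starting point. In this assay compound 1 gives > 10 ug/mL, which is a limit of the assay rather than a number. Compound 2 `COc1ccc(C(=O)/C=C/c2ccc3c(c2)B(O)OC3)cc1OC` gives in this assay > 10 ug/mL, again only a limit. Compound 3 `O=C(CCc1ccc2c(c1)B(O)OC2)c1ccccc1` likewise gives in this assay > 10 ug/mL, a limit as well. Compound 1 therefore stands where the other two stand; the shared picture is the limit of > 10 ug/mL in this assay, at which 3 of the 3 values shown sit, and no numerical ordering among the three can be drawn.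

Compound 4 `O=C(/C=C/c1ccc2c(c1)B(O)OC2)c1ccc(F)cc1` differs from compound 1 in one place: fluoro in place of methyl on an aromatic carbon. For the measured compounds named here, no step between two measured compounds is available to say how such a change moves the read-out in this assay. Compound 4 is expected to show no step beyond the scatter, the estimated step being a step that the limit leaves unreadable from compound 1 to compound 4. For compound 4 in this assay the expected half-maximal inhibitory concentration is 15 ug/mL, with a range from 7 ug/mL to 40 ug/mL, and most likely the assay will again report only a limit.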

Compound 4, half-maximal inhibitory concentration: > 10 ug/mL
Compound 4 was reported as a limit; the forecaster's own chance of this, stated with the estimate: 75%; the middle value is on the limit's open side.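

In this assay, for the compounds shown here, compound 4, like compound 1, is reported only as a limit, so no step between the two can be read. All the compounds share one picture: the limit of > 10 ug/mL in this assay, at which 4 of the 4 values shown sit. The compounds shown leave open where any of them would fall as a number, and whether fluoro in place of methyl moves the read-out at all.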